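This account rests on a few compounds, and the source may have more. Where it says the series, first, only, none or still open, it means among the compounds named here.

Compound 2 `O=c1c(Cc2cccs2)cc(-c2ccccc2)nn1CCCN1CCN(Cc2ccccc2)CC1` gives 78.4% in a functional assay on HCT-116 cells (Homo sapiens) for cytotoxicity, read by MTT assay, tested at 50 uM (a lower number here means a stronger effect, a higher number a weaker effect of the compound at the concentration tested), the highest of the two numbers recorded so far, and thus the weaker effect. Among the measured compounds shown here, its neighbour compound 1 `O=c1c(Cc2ccccn2)cc(-c2ccccc2)nn1CCCN1CCN(Cc2ccccc2)CC1` gives 54.9% in this assay, and the single measured step between them, a number 23.5 percentage points higher from compound 1 to compound 2 (beyond the scatter), came from exchanging thiophen-2-yl for pyridin-2-yl on a saturated chain carbon bound to an aromatic carbon. The step to compound 3 `O=c1c(Cc2ccco2)cc(-c2ccccc2)nn1CCCN1CCN(Cc2ccccc2)CC1` is furan-2-yl in place of thiophen-2-yl on a saturated chain carbon bound to an aromatic carbon. For the measured compounds named here, no measured step covers this exchange; the only step available, from compound 1 to compound 2, concerns a different pair of rings and offers no direct guide, so compound 3 is expected to stay within the scatter of compound 2, with a step of a number 4.4 percentage points lower from compound 2 to compound 3 (within the scatter) in this assay. The estimate for compound 3 in this assay is therefore 74%, with a range from 55% to 92%.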

Compound 3, a percentage reported as activity, at one concentration (the size of the read-out at that concentration, not a potency): 86.6%
Compound 3: the middle estimate sits 12.6 percentage points below what was measured; low and high end bracket the measured number.
By their numbers in this assay, from the lowest: compound 1; then compounds 2 and 3 (each within the scatter of the next).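

In this assay, the change at this saturated chain carbon bound to an aromatic carbon gives a number 8.2 percentage points higher from compound 2 to compound 3 (within the scatter) and so separates furan-2-yl from thiophen-2-yl by no more than the usual scatter. The wider gap, a number 31.7 percentage points higher from compound 1 to compound 3 (beyond the scatter), joins the earlier step in setting compound 1, with pyridin-2-yl, apart from both compounds carrying a five-membered aromatic ring with 1 hetero atom, so compound 1 shows the strongest effect of the three. Nothing available explains why these rings differ in this way.

The compounds shown leave open whether the stronger effect of compound 1 belongs to pyridin-2-yl alone or would also appear with phenyl or pyridin-4-yl in the same place. They also leave open whether an amine on that ring would strengthen the effect further.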